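Amine Substitution and Amide Exchange in Mouse Microsomal Clearance

The source may hold more compounds than are shown below. What is called first, only, known or untested is meant among the compounds shown, and "the series" means these compounds.

Compound 1 `C[C@H](NC(=O)[C@@H]1CCCN1C)c1ccc(NC(=O)N2CC(c3cccnc3)C2)cc1` was examined in an ADME assay on microsomes from liver (Mus musculus) for pharmacokinetics, read by LC-MS, using NADPH, with stated times of 5 min, 15 min and 30 min, tested at 10 uM (a higher number here means faster removal of the compound, a lower number slower removal), where compound 1 gives 40.8 mL.min-1.g-1. Compound 2 `CCC(=O)N[C@@H](C)c1ccc(NC(=O)N2CC(c3cccnc3)C2)cc1` differs from it by ethyl in place of 1-methylpyrrolidin-2-yl on a carbonyl carbon, and in this assay compound 2 gives 31.4 mL.min-1.g-1; the step is a 1.3-fold lower number from compound 1 to compound 2 (0.11 log units; within the scatter). Compound 3 `C[C@H](NC(=O)[C@@H]1CCCN1C)c1ccc(NC(=O)N2CC(c3ccc(N)nc3)C2)cc1` shares the core of compound 1 but carries amino in place of hydrogen on an aromatic carbon. For compound 3 this assay reports only a limit, < 25 mL.min-1.g-1. The step of an at least 1.6-fold lower number from compound 1 to compound 3 (0.21 log units; that floor lies within the scatter) therefore rests on the limit of < 25 mL.min-1.g-1 in this assay, at which 1 of the 3 values shown sits, and cannot be read further. Compound 4 `CCC(=O)N[C@@H](C)c1ccc(NC(=O)N2CC(c3ccc(N)nc3)C2)cc1` has not yet been measured in this assay; it stands to compound 3 as compound 2 stands to compound 1, the change being (ethyl in place of 1-methylpyrrolidin-2-yl on a carbonyl carbon), made at the same place in both pairs, so it is the same change. From compound 3 to compound 4 he expects a step that the limit leaves unreadable from compound 3 to compound 4, set beside a 1.3-fold lower number from compound 1 to compound 2 (0.11 log units; within the scatter), which was within the scatter, and resting on the limit at which compound 3 already sits (the limit of < 25 mL.min-1.g-1 in this assay, at which 1 of the 3 values shown sits). For compound 4 in this assay he therefore estimates 18 mL.min-1.g-1, with a range from 8 mL.min-1.g-1 to 32 mL.min-1.g-1, and a good chance that only a limit is reported again.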

Compound 4, intrinsic clearance in microsomes: 22 mL.min-1.g-1
Beside the measured number, compound 4's estimate is 1.2-fold (0.09 log units) below it; the range from low to high includes it.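

Amino in place of hydrogen on an aromatic carbon, carried onto the core of compound 2, gives a 1.4-fold lower number from compound 2 to compound 4 (0.15 log units; within the scatter) in this assay. Set beside the earlier case, the two steps read: the same change on two cores in this assay, an at least 1.6-fold lower number (0.21 log units; that floor lies within the scatter) from compound 1 to compound 3 and a 1.4-fold lower number (0.15 log units; within the scatter) from compound 2 to compound 4; the limit leaves it open whether they differ The result is therefore compatible with the change carrying from one core to the other, but it does not show that it does so to a like extent, nor does it show on either core a step that clears the usual scatter.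

Going by these compounds, the exchange of 1-methylpyrrolidin-2-yl for ethyl stays unreadable on the amino-bearing core, as the value of compound 3 is only a limit: the limit of < 25 mL.min-1.g-1 in this assay, at which 1 of the 4 values shown sits. Also open is whether a hydroxyl group or a methoxy group in place of the amino group, or a longer chain in place of ethyl, would give a step beyond the scatter in this assay.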